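The source may hold more compounds than are shown below. What is called first, only, known or untested is meant among the compounds shown, and "the series" means these compounds.

Among the measured compounds shown here, compound 2, with the structure `NC1CCN(c2c(-c3cc(F)cc(Cl)c3)cncc2-c2nc3cc(F)ccc3[nH]2)CC1`, is one of two compounds measured in a functional assay on CHO-K1 cells for agonist activity at somatostatin receptor type 2 (Homo sapiens), read by cAMP accumulation, with a stated time of 30 min; a higher number here means that more compound is needed for the effect, a lower number that less compound is needed. In this assay compound 2 gives 0.081 nM, the higher of the two numbers, so it needs more compound for the effect than its companion. Compound 1, the structure `Cc1cc(C)cc(-c2cncc(-c3nc4cc(C(F)(F)F)ccc4[nH]3)c2N2CCC(N)CC2)c1`, carries a different set of groups on the same shared core; in this assay compound 1 gives 0.014 nM, and the gap between compound 1 and compound 2 lies beyond the usual scatter of repeated measurements.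

The step under consideration leads from compound 2 to compound 3, the structure `Cc1cc(F)cc(-c2cncc(-c3nc4cc(F)ccc4[nH]3)c2N2CCC(N)CC2)c1`. The change is small and confined to one spot: methyl in place of chloro on an aromatic carbon. The rest of the molecule, including the amine-bearing ring and the shared core, stays unchanged.

For the measured compounds named here, no earlier pair among the measured compounds shows what this particular exchange does on its own. With so slight a change in size and no change in donors or acceptors, compound 3 is expected to land close to compound 2, the step from compound 2 to compound 3 estimated as a 1.4-fold lower number from compound 2 to compound 3 (0.13 log units; within the scatter), within the scatter. For compound 3 in this assay the estimate is 0.06 nM, with a range from 0.02 nM to 0.2 nM.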

Compound 3, half-maximal effective concentration: 0.019 nM
Estimate against measurement, compound 3: 3.2-fold (0.50 log units) above; measured number below the stated range.
By their numbers in this assay, from the lowest: compounds 1 and 3 (each within the scatter of the next); then compound 2.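

In this assay, exchanging chloro for methyl on this aromatic carbon has a measurable effect: the result is a 4.3-fold lower number from compound 2 to compound 3 (0.63 log units; beyond the scatter), a modest step, but one larger than the normal variation between repeated measurements. Among the compounds shown here, this is the first direct evidence that the assay distinguishes between these two groups at this position, even though the counts for the two groups match, with one heavy atom each and no hydrogen-bond donors or acceptors, and the change turns a 3-chloro-5-fluorophenyl group into a 3-fluoro-5-methylphenyl group while the rest of the molecule stays the same. No measurement available here explains why the number falls.

The compounds shown have only chloro or methyl on this carbon, so it remains open how an ethyl group, a methoxy group or a nitrile there would compare. This is also a single pair, which leaves open whether the same exchange would give a step of similar size if the other groups on the shared core were different.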